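Swapping an Azidomethyl Amide for an Unsaturated Chain

The source may report more compounds than this note shows. Statements on the series, on what has been measured and on what is new or still open speak of the compounds shown alone.

Measured compounds:
- Compound 1 `COc1ccc(CN(C(=O)CCCl)c2cc(OC)c(OC)c(OC)c2)cc1O`: 140 nM
- Compound 2 `COc1ccc(CN(C(=O)CN=[N+]=[N-])c2cc(OC)c(OC)c(OC)c2)cc1O`: 120 nM

Compound 2 gives the lowest number of the two in a functional assay on MGC-803 cells (Homo sapiens) for inhibition, read by MTT assay, with a stated time of 48 h (on this read-out lower numbers stand for stronger inhibition and higher numbers for weaker inhibition), but its neighbour compound 1 sits within the scatter, so the two cannot be ranked. The step of a 1.2-fold lower number from compound 1 to compound 2 (0.07 log units; within the scatter) shows that exchanging a chloromethyl for an azido group at the chain carbon beside the carbonyl leaves the read-out essentially unchanged.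

Compound 3 `CC/C=C/C(=O)N(Cc1ccc(OC)c(O)c1)c1cc(OC)c(OC)c(OC)c1` is not yet measured. For the measured compounds named here, its difference from compound 2 is but-1-en-1-yl in place of azidomethyl on a carbonyl carbon, a replacement at the carbonyl carbon that no measured pair has tested. Going by the values given here, the only step on record, from compound 1 to compound 2, concerns a different kind of exchange and was within the scatter, so it offers no clear direction.

Compound 3 is therefore expected near the measured pair, with the estimated step of a 1.3-fold higher number from compound 2 to compound 3 (0.12 log units; within the scatter). The estimate for compound 3 is 160 nM, in a range from 50 nM to 500 nM.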

Compound 3, half-maximal inhibitory concentration: 58 nM
Compound 3: the middle estimate sits 2.8-fold (0.44 log units) above what was measured; measured number inside the range.
By their numbers in this assay, from the lowest: compound 3; then compounds 2 and 1 (each within the scatter of the next).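

In this assay, the group on the carbonyl carbon now proves able to shift the number: but-1-en-1-yl in place of azidomethyl gives a 2.1-fold lower number from compound 2 to compound 3 (0.32 log units; beyond the scatter), and but-1-en-1-yl in place of 2-chloroethyl gives a 2.4-fold lower number from compound 1 to compound 3 (0.38 log units; beyond the scatter). Both steps are modest, yet unlike the earlier exchange of chloromethyl for azido, they lie beyond the scatter, so this position is not indifferent to what it carries. Nothing measured here explains why the number falls.

Going by these compounds, the double bond and the all-carbon chain enter together, so it remains open which of them matters; a saturated butyl chain or a shorter ethenyl group on the same carbonyl carbon would help separate them. On these data alone, how an amine at the end of the chain would behave also remains open.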